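Cyanobenzyl to methylbenzyl on the imidazole nitrogen

A few compounds are considered here, and "the series" means these few. Any claim that something is new, unique, unknown or untested is made for them only; others in the source may bear on it.

Compound 3 `CSCC[C@H](NC(=O)c1ccc(NCc2cncn2Cc2cccc(C#N)c2)cc1-c1ccccc1)C(=O)O` is one of three close analogues sharing a core. In a functional assay on NIH3T3 cells (Mus musculus) (on this read-out lower numbers stand for an effect already at smaller amounts and higher numbers for an effect only at larger amounts of compound), compound 3 reaches only the limit > 10 uM. Compound 1 `CSCC[C@H](NC(=O)c1ccc(NCc2cncn2Cc2ccccc2C#N)cc1-c1ccccc1)C(=O)O` likewise gives the limit > 10 uM. Compound 2 `CSCC[C@H](NC(=O)c1ccc(NCc2cncn2Cc2ccc(C#N)cc2)cc1-c1ccccc1)C(=O)O` also stops at the limit > 10 uM. Hence a step that the two limits leave unreadable from compound 1 to compound 2, a step that the two limits leave unreadable from compound 1 to compound 3 and a step that the two limits leave unreadable from compound 2 to compound 3 are all unreadable, since the limit of > 10 uM in this assay, at which 3 of the 3 values shown sit, covers every value so far. Compound 4 `CSCC[C@H](NC(=O)c1ccc(NCc2cncn2Cc2ccccc2C)cc1-c1ccccc1)C(=O)O` carries 2-methylphenyl in place of 3-cyanophenyl on a saturated chain carbon bound to an aromatic nitrogen. For the measured compounds named here, no measured step bears on this change, and the nitrile position changes gave no readable size. The step that the limit leaves unreadable from compound 3 to compound 4 from compound 3 to compound 4 is therefore expected to be none beyond the scatter, most likely again a limit. Compound 4 is estimated at 15 uM, with a range of 4 uM to 60 uM in this assay.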

Compound 4, concentration for half-maximal effect: > 10 uM
Compound 4: no number, only a limit (the forecaster's own chance of this, stated with the estimate: 80%); the middle value is on the limit's open side.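

In this assay, for the compounds shown here, compound 4 gives > 10 uM as a limit, and no step from compound 1, compound 2 or compound 3 to compound 4 can be read: the limit of > 10 uM in this assay, at which 4 of the 4 values shown sit. In this assay the size of any change from cyanophenyl to 2-methylphenyl stays open with the compounds shown.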